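Vero cytotoxicity notes: ethyl in place of fluoro

This account rests on a few compounds, and the source may have more. Where it says the series, first, only, none or still open, it means among the compounds named here.

Compound 1 `CCN(CC)c1cc2[nH]c(C3CCCCC3)nc2cc1NC(=O)c1ccc(F)cc1` has been tested in an ADME assay on Vero cells (Chlorocebus sabaeus) for cytotoxicity, read by resazurin assay, with a stated time of 3 days; a lower number here means a stronger inhibitor, a higher number a weaker inhibitor. Compound 1 gives > 100 ug/mL, which is a limit of the assay rather than a number. Compound 2 `CN(C)c1cc2[nH]c(C3CCCCC3)nc2cc1NC(=O)c1ccc(C(C)(C)C)cc1` in this assay gives > 100 ug/mL, again a limit of the assay. Both known values sit at the limit of > 100 ug/mL in this assay, at which 2 of the 2 values shown sit, so no step between measured compounds can be read, and compound 1 stands at the same limit as the one other compound shown. Compound 3 `CCc1ccc(C(=O)Nc2cc3nc(C4CCCCC4)[nH]c3cc2N(CC)CC)cc1` is not yet measured. It differs from compound 1 by ethyl in place of fluoro on an aromatic carbon. Among the measured compounds shown here, with no measured step to draw on and both known values at the same limit, no change beyond the scatter is expected for the step of a number no higher from compound 1 to compound 3 (the limit leaves the size open). Compound 3 is expected to give about 100 ug/mL in this assay, within 50 ug/mL to 200 ug/mL, most likely again reported only as a limit.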

Compound 3, half-maximal inhibitory concentration: > 100 ug/mL
Compound 3: only a limit was reported; the forecaster's own chance of this, stated with the estimate: 75%; the middle value sits exactly at the limit.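

In this assay compound 3 gives > 100 ug/mL as a limit of the assay and not a number. Among the compounds shown here, compound 1 also stands at a limit, so no step between compound 1 and compound 3 can be read: the limit of > 100 ug/mL in this assay, at which 3 of the 3 values shown sit. The compounds shown leave open whether ethyl in place of fluoro changes the read-out at all.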